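Cyclopentyl carbamate in place of tert-butyl carbamate

A few compounds are considered here, and "the series" means these few. Any claim that something is new, unique, unknown or untested is made for them only; others in the source may bear on it.

Measured so far:
compound 1 `COc1cnc(O[C@@H]2C[C@@H](C(=O)N[C@]3(C(=O)NS(=O)(=O)C4CC4)C[C@H]3C(C)C)N(C(=O)[C@@H](NC(=O)OC(C)(C)C)C(C)(C)C)C2)c2cc(Cl)ccc12`: 1.38 h
compound 2 `COc1cnc(O[C@@H]2C[C@@H](C(=O)N[C@]3(C(=O)NS(=O)(=O)C4CC4)C[C@H]3C3CC3)N(C(=O)[C@@H](NC(=O)OC(C)(C)C)C(C)(C)C)C2)c2cc(Cl)ccc12`: 1.38 h

In an ADME assay on liver (Homo sapiens) for metabolic stability, using microsomes (on this read-out higher numbers stand for a longer-lived compound and lower numbers for a shorter-lived compound), compound 1 gives 1.38 h and compound 2 gives 1.38 h. For the measured compounds named here, the only measured step, no change at the digits printed from compound 1 to compound 2 (within the scatter), swaps cyclopropyl for isopropyl on a saturated ring carbon and leaves the half-life where it was; compound 2 therefore stands level with compound 1.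

Compound 3 `COc1cnc(O[C@@H]2C[C@@H](C(=O)N[C@]3(C(=O)NS(=O)(=O)C4CC4)C[C@H]3C3CC3)N(C(=O)[C@@H](NC(=O)OC3CCCC3)C(C)(C)C)C2)c2cc(Cl)ccc12` differs from compound 2 at another place: cyclopentyl in place of tert-butyl on an oxygen next to a carbonyl group. Going by the values given here, no measured pair touches this part of the shared core, so the one known step offers no guide to the direction or size of the change in this assay. The expectation is therefore a step close to nothing, a 1.2-fold lower number from compound 2 to compound 3 (0.06 log units; within the scatter), with wide uncertainty. Compound 3 is estimated at 1.2 h, between 0.5 h and 2.8 h.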

Compound 3, half-life: 0.65 h
Estimate against measurement, compound 3: 1.8-fold (0.27 log units) above, within the range that was stated.
By their numbers in this assay, from the lowest: compound 3; then compounds 1 and 2 (each within the scatter of the next).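

In this assay, cyclopentyl in place of tert-butyl on an oxygen next to a carbonyl group gives a 2.1-fold lower number from compound 2 to compound 3 (0.33 log units; beyond the scatter). For the compounds shown here, the earlier change, at another place in the molecule, gave no change at the digits printed from compound 1 to compound 2 (within the scatter) and left the half-life where it was, so this carbamate group is the first place where a change moves the number beyond the scatter, though only modestly. Nothing measured here accounts for the lower number.

Going by these compounds, a single pair cannot separate the effect of having a ring from that of its size, so it remains open where cyclobutyl, cyclohexyl or isopropyl on the same oxygen would fall. On these data alone, it is also open whether the same swap would give a similar step with the isopropyl group of compound 1 in place of cyclopropyl.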